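The compounds below may be only part of what the source reports. "The series", "measured", "known", "first", "only" and "open" are said of these compounds alone.

Series notes. Compound 1 `Cn1c(-c2ccc(NC(=O)CSc3nc4ccccc4o3)cc2)nc(-c2ccccc2)c1-c1ccccc1` gives 79.3% in a functional assay on HT-29 cells (Homo sapiens) for cytotoxicity, read by MTT assay, with a stated time of 24 h, tested at 32 ug/mL; a lower number here means a weaker effect, a higher number a stronger effect of the compound at the concentration tested. Compound 2 `Cc1ccc2oc(SCC(=O)Nc3ccc(-c4nc(-c5ccccc5)c(-c5ccccc5)n4C)cc3)nc2c1` gives 59.5% in this assay; the change methyl in place of hydrogen on an aromatic carbon produced the step of a number 19.8 percentage points lower from compound 1 to compound 2 (beyond the scatter). Compound 3 `Cn1c(-c2ccc(NC(=O)CN3CCN(Cc4ccccc4)CC3)cc2)nc(-c2ccccc2)c1-c1ccccc1` gives 40% in this assay; the difference between the core of compound 3 and the core of compound 1 is not broken down here. Compound 4 `Cc1ccc(CN2CCN(CC(=O)Nc3ccc(-c4nc(-c5ccccc5)c(-c5ccccc5)n4C)cc3)CC2)cc1` carries the change (methyl in place of hydrogen on an aromatic carbon), the same kind of change as from compound 1 to compound 2, though the surroundings differ: in compound 2 the methyl sits on a ring that is part of a fused or bridged system of two rings, meta to a fused ring and para to a fused ring, whereas in compound 4 it sits para to a large group. Among the compounds with values here, a step of a number 10 percentage points lower from compound 3 to compound 4 (within the scatter) is expected, resting on the only precedent, the step of a number 19.8 percentage points lower from compound 1 to compound 2 (beyond the scatter), applied to compound 3, whose value is 40%. Compound 4 is therefore estimated at 30%, between 15% and 48%.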

Compound 4, a percentage reported as activity, at one concentration (the size of the read-out at that concentration, not a potency): 42.3%
Compound 4: middle estimate off by 12.3 percentage points, on the low side; measured number inside the range.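

Methyl in place of hydrogen on an aromatic carbon gives a number 2.3 percentage points higher from compound 3 to compound 4 (within the scatter) in this assay. The change therefore does not carry a fixed size from one core to the other: the same change on two cores in this assay, a number 19.8 percentage points lower (beyond the scatter) from compound 1 to compound 2 and a number 2.3 percentage points higher (within the scatter) from compound 3 to compound 4, 22.1 percentage points apart, beyond the scatter of two such steps. This rests on one pair per core, with the methyl in different surroundings in each pair, so it does not show whether the core or the surroundings of the methyl set the two steps apart.

The compounds shown leave open whether a methoxy group or a chlorine atom in place of this methyl would also give steps that differ between the two cores. They also leave open how an ethyl group at the same place would read.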